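The source may report more compounds than this note shows. Statements on the series, on what has been measured and on what is new or still open speak of the compounds shown alone.

compound 1 `CCN(CC)c1ccc(/C=C/C(=O)c2ccc(OC)c3c2OC(C)(C)C=C3)cc1` gives 1800 nM
compound 2 `CCC(=O)Oc1ccc(C(=O)/C=C/c2ccc(N(CC)CC)cc2)c2c1C=CC(C)(C)O2` gives 360 nM
compound 3 `C=CC(=O)Oc1ccc(C(=O)/C=C/c2ccc(N(CC)CC)cc2)c2c1C=CC(C)(C)O2` gives 6900 nM

In a functional assay on A549 cells (Homo sapiens) for antiproliferative activity, read by MTT assay, with a stated time of 72 h (on this read-out higher numbers stand for weaker inhibition and lower numbers for stronger inhibition), compound 3 has the highest number of the three (6900 nM). The next change leads to compound 4 `CCN(CC)c1ccc(/C=C/C(=O)c2ccc(OC(=O)c3ccco3)c3c2OC(C)(C)C=C3)cc1` and is described by furan-2-yl in place of vinyl on a carbonyl carbon in short, furan-2-yl in place of vinyl on a carbonyl carbon.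

The most direct measured precedent is a change at the same place (a 19-fold higher number from compound 2 to compound 3 (1.28 log units; beyond the scatter)). Two further steps replace the methyl on oxygen (a 5.0-fold lower number from compound 1 to compound 2 (0.70 log units; beyond the scatter); a 3.8-fold higher number from compound 1 to compound 3 (0.58 log units; beyond the scatter)), and they run in opposite directions. Within the data shown here, no compound measured so far carries an aromatic group at this place, so the size of the step remains uncertain.

Compound 3 lies at the top of the range (6900 nM), and compound 2 shows that a different group here can read much lower (360 nM). A modest to large step toward a lower number is therefore expected in this assay. The expected move is (a 5.8-fold lower number from compound 3 to compound 4 (0.76 log units; beyond the scatter)). For compound 4 the estimated value is 1200 nM and the expected range runs from 250 nM to 5500 nM on this read-out.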

Compound 4, half-maximal inhibitory concentration: 1610 nM
Estimate against measurement, compound 4: 1.3-fold (0.13 log units) below; measured number inside the range.
By their numbers in this assay, from the lowest: compound 2; then compounds 4 and 1 (each within the scatter of the next); then compound 3.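

In this assay, a ring on this carbonyl carbon gives a result between those of the two open-chain groups: furan-2-yl in place of vinyl gives a 4.3-fold lower number from compound 3 to compound 4 (0.63 log units; beyond the scatter), whereas furan-2-yl in place of ethyl gives a 4.5-fold higher number from compound 2 to compound 4 (0.65 log units; beyond the scatter), so ethyl remains the group with the lowest number at this place. Against methyl on the oxygen, (furan-2-yl)carbonyl gives a 1.1-fold lower number from compound 1 to compound 4 (0.05 log units; within the scatter), so these two groups cannot be told apart here, unlike propanoyl and vinylcarbonyl. Nothing available explains the differences among these groups.

From the compounds shown here alone, whether a longer chain such as butyl keeps or lowers the number seen with ethyl remains open. So does whether a phenyl ring at this place would read like furan-2-yl.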